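Bis-sulfonamide series: shifting fluorine on one aryl ring

The compounds below may be only part of what the source reports. "The series", "measured", "known", "first", "only" and "open" are said of these compounds alone.

Measured compounds in an assay for inhibition of liver carboxylesterase 1 (Homo sapiens), read by spectrophotometry; on this read-out higher numbers stand for weaker inhibition and lower numbers for stronger inhibition:
compound 1, `O=S(=O)(Nc1ccc(NS(=O)(=O)c2cccc(Br)c2)cc1)c1cccc(Br)c1`, gives > 100000 nM, which is a limit of the assay.
compound 2, `Cc1ccc(S(=O)(=O)Nc2ccc(NS(=O)(=O)c3ccc(F)cc3F)cc2)cc1`, gives > 100000 nM, also a limit.
compound 3, `O=S(=O)(Nc1c(F)c(F)c(NS(=O)(=O)c2ccc(F)cc2)c(F)c1F)c1ccc(F)cc1`, gives > 100000 nM, again a limit.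

Among the measured compounds shown here, compound 2 stands nowhere distinct on these numbers: every value shown is the limit of > 100000 nM in this assay, at which 3 of the 3 values shown sit, so no compound in the set yields a measurable inhibition constant, and no step between measured compounds can be placed. Compound 4, `Cc1ccc(S(=O)(=O)Nc2ccc(NS(=O)(=O)c3cc(F)ccc3F)cc2)cc1`, keeps everything of compound 2 except one change: 2,5-difluorophenyl in place of 2,4-difluorophenyl on a sulfonyl sulfur. For the measured compounds named here, with no measured step to lean on, the change is expected to bring no step beyond the scatter, most probably leaving compound 4 at the same limit. The estimate for compound 4 in this assay is 200000 nM, with a range from 50000 nM to 1000000 nM. This estimate means an expected step that the limit leaves unreadable from compound 2 to compound 4.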

Compound 4, inhibition constant: > 100000 nM
Compound 4: a limit, no number; the forecaster's own chance of this, stated with the estimate: 85%; the middle value lies beyond the limit too.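

In this assay no step can be read between compound 2 and compound 4, because both stand at a limit of the assay: the limit of > 100000 nM in this assay, at which 4 of the 4 values shown sit.

The compounds shown leave open whether 2,5-difluorophenyl and 2,4-difluorophenyl differ at all, since none gives a measurable inhibition constant.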